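The source may report more compounds than this note shows. Statements on the series, on what has been measured and on what is new or still open speak of the compounds shown alone.

Within the data shown here, compound 1 `N=C(N)NCCC[C@H](NC(=O)CN(c1ncnc2c1ncn2C1CCCCO1)C1CC1)C(=O)OCc1ccccc1` heads the two numbers so far: in a functional assay on the whole organism (Tail, strain ICR) with Mus musculus as the target, in the tail flick test, with a stated time of 60 min, at a dose of 25 umol/kg by the oral route (on this read-out lower numbers stand for a weaker effect and higher numbers for a stronger effect at the one dose given), compound 1 gives 52.4%, while compound 2 `O=C(CN(c1nc(Cl)nc2[nH]cnc12)C1CC1)NCC(=O)OCc1ccccc1` gives 41.9% in this assay, a gap beyond the scatter. Among the measured compounds shown here, no step between measured compounds is recorded, so the move to compound 3 `NC(=O)C[C@H](NC(=O)CN(c1ncnc2c1ncn2C1CCCCO1)C1CC1)C(=O)OCc1ccccc1` rests on the structural change alone: a group of 3 heavy atoms (1 carbon, 1 nitrogen, 1 oxygen; no ring) in place of a group of 6 heavy atoms (3 carbon, 3 nitrogen; no ring), on a saturated chain carbon, two bonds along the chain from an amide-type nitrogen and a carbonyl carbon. With nothing in the series to anchor the size of such a swap, a moderate fall in this assay is expected, a number 12.4 percentage points lower from compound 1 to compound 3 (beyond the scatter), rather than no change. Compound 3 is estimated at 40% in this assay, with a range of 20% to 60%.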

Compound 3, a percentage reported as activity, at one dose (the size of the read-out at that dose, not a potency): 30.5%
Beside the measured number, compound 3's estimate is 9.5 percentage points above it; measured number inside the range.
By their numbers in this assay, from the lowest: compound 3; then compound 2; then compound 1.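

Among these compounds, the first single-place comparison falls on the saturated chain carbon, two bonds along the chain from an amide-type nitrogen and a carbonyl carbon. With carbamoyl in place of the group of 6 heavy atoms, the read-out in this assay shows a clear step (a number 21.9 percentage points lower from compound 1 to compound 3 (beyond the scatter)), so this position is not indifferent to the group it carries. Nothing available explains the fall.

As far as these compounds go, whether an amine or a carboxylic acid here would stand nearer compound 1 or compound 3 remains open. So does whether the same swap would give a similar step on the core of compound 2.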